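The source may report more compounds than this note shows. Statements on the series, on what has been measured and on what is new or still open speak of the compounds shown alone.

Measured compounds in an assay on HEK293 cells for binding affinity to Urotensin-2 receptor (Homo sapiens), read by radioligand binding; on this read-out higher numbers stand for weaker inhibition and lower numbers for stronger inhibition:
- compound 1, `CN(C)CCCOc1ccc(CN2CC[C@H](NC(=O)c3cc(Cl)cc(Cl)c3)C2)cc1`: 2000 nM
- compound 2, `Cc1cc(C(=O)N[C@H]2CCN(Cc3ccc(OCCCN(C)C)cc3)C2)ccc1Br`: 631 nM
- compound 3, `CN(C)CCCOc1ccc(CN2CC[C@H](NC(=O)c3cccs3)C2)cc1`: < 10000 nM

Compound 3, `CN(C)CCCOc1ccc(CN2CC[C@H](NC(=O)c3cccs3)C2)cc1`, stands apart from the other two in that its result is only a limit of this assay, < 10000 nM, as noted in the limit of < 10000 nM in this assay, at which 1 of the 3 values shown sits. Compound 3 therefore cannot be placed in order against compound 1 or compound 2; the steps from compound 1 to compound 3 and from compound 2 to compound 3 are both unreadable for this reason. Among the measured compounds shown here, the one readable step among the measured compounds is a 3.2-fold lower number from compound 1 to compound 2 (0.50 log units; beyond the scatter), a modest shift that comes from swapping one aromatic group on the carbonyl carbon for another.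

Compound 4, `CN(C)CCCOc1ccc(CN2CC[C@H](NC(=O)c3cc4ccccc4o3)C2)cc1`, has not yet been measured. It differs from compound 3 in a single place: 1-benzofuran-2-yl in place of thiophen-2-yl on a carbonyl carbon. For the measured compounds named here, since the only readable step concerns different aromatic groups at the same carbonyl carbon, and since compound 3 itself gives no number, the data offer no measured step that directly fixes the size or direction of the change to compound 4. The step expected from the estimate below is a step that the limit leaves unreadable from compound 3 to compound 4, which cannot be read against a limit. Compound 4 is estimated to give about 1500 nM in this assay, with a range from 300 nM to 8000 nM.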

Compound 4, inhibition constant: 2510 nM
For compound 4 the middle estimate is 1.7-fold (0.22 log units) below the measured one; low and high end bracket the measured number.
By their numbers in this assay, from the lowest: compound 2; then compounds 1 and 4 (each within the scatter of the next).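

Compound 4 shows that a two-ring aromatic group on this carbonyl carbon can give a readable number in this assay, which the thiophen-2-yl of compound 3 did not provide. Compound 3 has only a limit, so the effect of replacing thiophen-2-yl with 1-benzofuran-2-yl cannot be sized, and all steps involving compound 3 remain unreadable because of that limit: the limit of < 10000 nM in this assay, at which 1 of the 4 values shown sits. Against the two substituted phenyl groups, the new group gives a 1.3-fold higher number from compound 1 to compound 4 (0.10 log units; within the scatter), which leaves it level with 3,5-dichlorophenyl, and a 4.0-fold higher number from compound 2 to compound 4 (0.60 log units; beyond the scatter), which leaves 4-bromo-3-methylphenyl as the better of these two groups at this position.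

The compounds shown leave open whether the readable number of compound 4 depends on the added six-membered ring or on the oxygen in place of sulfur, a question that 1-benzothiophen-2-yl or furan-2-yl on the same carbonyl carbon would address. They also leave open how much of the lower number of compound 2 belongs to the bromine and how much to the methyl, which an unsubstituted phenyl, 4-bromophenyl or 3-methylphenyl would help separate.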